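Methoxy count on the aryl ring and tolerated concentration

The source may hold more compounds than are shown below. What is called first, only, known or untested is meant among the compounds shown, and "the series" means these compounds.

Measured so far:
compound 1, `COc1ccc(-c2cc(/C=C/C(=O)c3ccc(N)cc3)[nH]n2)cc1`: 58100 nM
compound 2, `COc1cc(-c2cc(/C=C/C(=O)c3ccc(N)cc3)[nH]n2)cc(OC)c1OC`: 27600 nM

Both numbers come from a functional assay on 786-0 cells (Homo sapiens) for inhibition, read by sulforhodamine B assay, with a stated time of 48 h; a lower number here means that less compound is tolerated, a higher number that more compound is tolerated. Compound 2 stands lowest of the two, with compound 1 giving the higher number, a gap beyond the usual scatter, so less of compound 2 is tolerated than of compound 1.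

Compound 3, `COc1ccc(-c2cc(/C=C/C(=O)c3ccc(N)cc3)[nH]n2)cc1OC`, is not yet measured in this assay. It differs from compound 2 by hydrogen in place of methoxy on an aromatic carbon, a removal on an aromatic carbon of a six-membered aromatic ring of carbon only, ortho to a methoxy group and meta to a large group and to a methoxy group.

Within the data shown here, with no measured step of this kind available, the expectation rests on the two values alone: compound 3 carries fewer methoxy groups than compound 2 and more than compound 1, so a number between the two is expected. For compound 3 an estimate of 40000 nM is made, within 20000 nM to 80000 nM, meaning an expected step of a 1.4-fold higher number from compound 2 to compound 3 (0.16 log units; within the scatter), likely within or at the edge of the scatter.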

Compound 3, concentration lethal to 50% of the cells: 10800 nM
Estimate against measurement, compound 3: 3.7-fold (0.57 log units) above; measured number outside the range, below it.
By their numbers in this assay, from the lowest: compound 3; then compound 2; then compound 1.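

In this assay, hydrogen in place of methoxy on an aromatic carbon, ortho to a methoxy group, gives a 2.6-fold lower number from compound 2 to compound 3 (0.41 log units; beyond the scatter), while methoxy in place of hydrogen on an aromatic carbon gives a 5.4-fold lower number from compound 1 to compound 3 (0.73 log units; beyond the scatter). Both single changes therefore lead down to compound 3, which carries fewer methoxy groups than compound 2 and more than compound 1, so across these three compounds the number does not follow the methoxy count and the placement of the groups on the ring matters. Nothing at hand explains this turn in the series.

The compounds shown leave open whether another group at this carbon, such as a hydroxyl, an ethoxy group or an amine, would go with a number like that of compound 3 or compound 2. They also leave open whether the same pattern holds in other cell lines.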